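Adding a Carboxymethyl Group to Compound 3

This account rests on a few compounds, and the source may have more. Where it says the series, first, only, none or still open, it means among the compounds named here.

Measured in a functional assay on K562 cells (Homo sapiens) for antiproliferative activity, read by MTT assay, with a stated time of 72 h; a lower number here means a stronger inhibitor, a higher number a weaker inhibitor:
Compound 1, `O=C1NC(=S)S/C1=C\C1=Cc2cc(Br)ccc2OC1`, gives 33700 nM.
Compound 2, `O=C(O)CN1C(=O)/C(=C/C2=Cc3cc(Br)ccc3OC2)SC1=S`, gives only a limit, > 25000 nM.
Compound 3, `CC1Oc2ccc(Br)cc2C=C1/C=C1\SC(=S)NC1=O`, gives 31600 nM.

Compound 3 carries a methyl on a saturated ring carbon where compound 1 has hydrogen, and the step of a 1.1-fold lower number from compound 1 to compound 3 (0.03 log units; within the scatter) leaves the two numbers within the usual scatter of each other. Compound 2 in this assay is a limit, not a number.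

Compound 4, `CC1Oc2ccc(Br)cc2C=C1/C=C1\SC(=S)N(CC(=O)O)C1=O`, differs from compound 3 in one place: carboxymethyl in place of hydrogen on an amide-type nitrogen in a ring. Among the measured compounds shown here, the only measured step with the same change is from compound 1 to compound 2, and its size is a step that the limit leaves unreadable from compound 1 to compound 2 because the limit of > 25000 nM in this assay, at which 1 of the 3 values shown sits, caps the value. Hence the direction is toward a weaker compound, but the size is open, and a limit may again be reported.

Compound 4 is expected to give about 40000 nM, estimated between 15000 nM and 150000 nM. For compound 4 this means an expected step of a 1.3-fold higher number from compound 3 to compound 4 (0.10 log units; within the scatter).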

Compound 4, half-maximal inhibitory concentration: > 50000 nM
Compound 4 gave a limit, no number; the forecaster's own chance of this, stated with the estimate: 60%; middle value at least 1.2-fold (0.09 log units) from the limit.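

In this assay, among the compounds shown here, putting carboxymethyl on the amide-type nitrogen of the methyl-bearing compound gives an at least 1.5-fold higher number from compound 3 to compound 4 (0.19 log units; that floor lies within the scatter), the first step for this change with a readable floor, which the pair of compound 1 and compound 2 could not offer. That floor lies within the scatter, so this step alone does not establish a real weakening. Compound 4 is a limit and not a number, so on both cores shown the carboxymethyl compound lacks a number: the limit of > 50000 nM in this assay, at which 1 of the 4 values shown sits.

On these data alone, the step from compound 2 to compound 4 cannot be read, so what the methyl on the saturated ring carbon does alongside carboxymethyl stays open. Also open, as far as these compounds go, are the true size of the carboxymethyl step and what a longer chain ending in an amine, or a methyl ester of the acid, would give on this nitrogen.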